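Alkyne-bearing nitrochromenes as P2Y6 antagonists

A few compounds are considered here, and "the series" means these few. Any claim that something is new, unique, unknown or untested is made for them only; others in the source may bear on it.

Three compounds sharing a nitro-substituted, trifluoromethyl-bearing core have numbers in an assay on 1321N1 cells for antagonist activity at P2Y purinoceptor 6 (Homo sapiens), read by FLIPR and calcium flux; on this read-out higher numbers stand for weaker inhibition and lower numbers for stronger inhibition. Compound 1 `CC[Si](C#Cc1cccc2c1OC(C(F)(F)F)C([N+](=O)[O-])=C2)(CC)CC` gives 461 nM in this assay. Compound 2 `O=[N+]([O-])C1=Cc2cc(C#Cc3ccc(CO)cc3)ccc2OC1C(F)(F)F` gives 2000 nM in this assay and holds the second highest of the three numbers; compound 1 sits at a lower number, beyond the scatter, and compound 3 `O=[N+]([O-])C1=Cc2c(Cl)cccc2OC1C(F)(F)F`, which gives 15700 nM in this assay, sits at a higher number, also beyond the scatter. For the measured compounds named here, no pair among the measured compounds differs in a single place, so the size of any one change is not known from these data.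

Compound 4 `O=[N+]([O-])C1=Cc2cc(C#Cc3ccc(C(F)(F)F)cc3)ccc2OC1C(F)(F)F` is not yet measured. It differs from compound 2 by trifluoromethyl in place of hydroxymethyl on an aromatic carbon. Both the hydroxymethyl group and the trifluoromethyl group are carried on the same aryl alkyne, so the shape of the larger substituent is kept. The step of a 1.5-fold lower number from compound 2 to compound 4 (0.19 log units; within the scatter) is expected to stay within the scatter or move only modestly toward lower numbers. Compound 4 is therefore estimated at 1300 nM in this assay, within a range from 400 nM to 4000 nM.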

Compound 4, half-maximal inhibitory concentration: 5220 nM
For compound 4 the middle estimate is 4.0-fold (0.60 log units) below the measured one; measured number above the stated range.
By their numbers in this assay, from the lowest: compound 1; then compound 2; then compound 4; then compound 3.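

In this assay, for the compounds shown here, trifluoromethyl in place of hydroxymethyl on the aromatic carbon gives a 2.6-fold higher number from compound 2 to compound 4 (0.42 log units; beyond the scatter), the first single-place comparison. The substituent on this aryl alkyne therefore matters to the read-out: the change moves the number toward weaker inhibition, beyond the scatter, so hydroxymethyl is the better of the two groups here. Nothing available explains the step, and this one pair cannot separate the loss of the hydrogen-bond donor and acceptor counted for hydroxymethyl from the larger heavy-atom count of trifluoromethyl.

From the compounds shown here alone, whether an amine, a carboxylic acid or a methoxy group at this place would give a lower number than hydroxymethyl remains open. Also open, going by these compounds, is whether a longer chain ending in hydroxyl would keep or lose what hydroxymethyl gives.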